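The source may report more compounds than this note shows. Statements on the series, on what has been measured and on what is new or still open speak of the compounds shown alone.

Measured in an assay on HepG2 cells for activation of nuclear factor erythroid 2-related factor 2 (Homo sapiens), read by a luciferase reporter, with a stated time of 5 h; a higher number here means that more compound is needed for the effect, a lower number that less compound is needed:
- compound 1 `Fc1ccccc1/C=C/c1ccccc1` gives 700 nM
- compound 2 `Fc1cccc(F)c1/C=C/c1ccccc1` gives 6900 nM
- compound 3 `Fc1cccc(/C=C/c2ccccc2F)c1` gives > 15000 nM, which is a limit of the assay and not a number.

Compound 1 stands at the lowest of the two numbers in this assay. Its nearest neighbour is reached by the step of a 9.9-fold higher number from compound 1 to compound 2 (0.99 log units; beyond the scatter), which is the nearest measured value. Compound 3 sits at the limit of > 15000 nM in this assay, at which 1 of the 3 values shown sits, so only a limit is known for it.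

Compound 4 `Fc1ccc(/C=C/c2ccccc2F)cc1` is not yet measured. It differs from compound 1 by fluoro in place of hydrogen on an aromatic carbon.

For the measured compounds named here, two measured steps bear on this change, and both are of the same kind, a fluoro in place of a hydrogen on an aromatic carbon of the shared core of compound 1. The first, a 9.9-fold higher number from compound 1 to compound 2 (0.99 log units; beyond the scatter), is modest. The second, an at least 21-fold higher number from compound 1 to compound 3 (1.33 log units; beyond the scatter), is large and ends at a limit. Neither added fluoro left the number where compound 1 had it, and both pushed it upward, beyond the scatter. A rise in the number is therefore expected here as well, that is, more compound needed for the effect.

Compound 4 is expected to give about 7000 nM, with a likely range from 1500 nM to 30000 nM, a step of a 10-fold higher number from compound 1 to compound 4 (1.00 log units; beyond the scatter) in this assay.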

Compound 4, half-maximal effective concentration: 3600 nM
Beside the measured number, compound 4's estimate is 1.9-fold (0.29 log units) above it; low and high end bracket the measured number.
By their numbers in this assay, from the lowest: compound 1; then compounds 4 and 2 (each within the scatter of the next). At a limit, above all of these: compound 3.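

The new step, a 5.1-fold higher number from compound 1 to compound 4 (0.71 log units; beyond the scatter), shows that a fluoro placed on an aromatic carbon, para to a group of 9 heavy atoms, also raises the number in this assay, so this position does not leave the value of compound 1 unchanged either. All three fluoro additions shown now point the same way, with no compound among them going against this pattern, and compound 1, which carries no added fluoro, keeps the lowest number of the set. Compound 4 also gives a real number at this position, whereas compound 3 stays a limit of the assay and not a number: the limit of > 15000 nM in this assay, at which 1 of the 4 values shown sits.

The compounds shown test only fluoro as the incoming group, so it remains open whether a different group at this position, such as a chlorine atom, a methoxy group or an amine, would raise the number as well or lower it. They also cannot say why each added fluoro raises the number, or whether removing the fluoro already present in compound 1 would move the number at all.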